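Imidazolyl to piperazinyl on the butyl-bearing aromatic position

The source may report more compounds than this note shows. Statements on the series, on what has been measured and on what is new or still open speak of the compounds shown alone.

Measured in a functional assay on U-251 cells (Homo sapiens) for inhibition, read by sulforhodamine B assay, with a stated time of 72 h; on this read-out higher numbers stand for an effect only at larger amounts of compound and lower numbers for an effect already at smaller amounts:
compound 1 `CCC(=O)Oc1cccc2ccc(/C=C/c3ccccc3[N+](=O)[O-])nc12` gives 10100 nM
compound 2 `CCCCc1ccc(C(=O)/C=C/c2ccc([N+](=O)[O-])o2)cc1` gives 3900 nM
compound 3 `O=C(/C=C/c1ccc([N+](=O)[O-])o1)c1ccc(-n2ccnc2)cc1` gives 22600 nM

Compound 3 stands highest of the three numbers, with compound 1 nearer to it than compound 2. Compound 4 `O=C(/C=C/c1ccc([N+](=O)[O-])o1)c1ccc(N2CCNCC2)cc1` is still unmeasured. It has piperazin-1-yl in place of 1H-imidazol-1-yl on an aromatic carbon, para to a large group: piperazin-1-yl in place of 1H-imidazol-1-yl on an aromatic carbon. Among the compounds with values here, one measured step bears on this place: a 5.8-fold higher number from compound 2 to compound 3 (0.76 log units; beyond the scatter), a modest change beyond the scatter with butyl leaving and 1H-imidazol-1-yl entering. Within the data shown here, no measured step involves piperazin-1-yl, so this single step is only a rough guide to size. Among the measured compounds shown here, compound 1 differs from the others in more than one place and gives no step. A modest move toward a lower number is expected in this assay, no larger than the measured step, though the direction remains uncertain. The expected change is a 2.1-fold lower number from compound 3 to compound 4 (0.31 log units; beyond the scatter). For compound 4 the estimate is 11000 nM, with an expected range from 3500 nM to 32000 nM.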

Compound 4, half-maximal effective concentration: 16700 nM
Beside the measured number, compound 4's estimate is 1.5-fold (0.18 log units) below it; the measured number falls inside the stated range.
By their numbers in this assay, from the lowest: compound 2; then compounds 1, 4 and 3 (each within the scatter of the next, the first and the last beyond it).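

In this assay, exchanging 1H-imidazol-1-yl for piperazin-1-yl gives a 1.4-fold lower number from compound 3 to compound 4 (0.13 log units; within the scatter), so this position tolerates the change from a five-membered aromatic ring to a six-membered non-aromatic ring, with one added hydrogen-bond donor, without a change beyond the scatter. Butyl now stands apart from two different ring substituents, since a 5.8-fold higher number from compound 2 to compound 3 (0.76 log units; beyond the scatter) is joined by a 4.3-fold higher number from compound 2 to compound 4 (0.63 log units; beyond the scatter), and the earlier single step could not show that this separation extends past 1H-imidazol-1-yl. No data on hand explain either step.

Still open, on these data alone, is whether a morpholin-4-yl ring, a 4-methylpiperazin-1-yl ring or a carboxylic acid on this aromatic carbon would stay level with compound 3 and compound 4 or move toward compound 2. A chain longer than butyl or a shorter one such as ethyl would show how far the number of compound 2 depends on chain length.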